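A few compounds are considered here, and "the series" means these few. Any claim that something is new, unique, unknown or untested is made for them only; others in the source may bear on it.

Measured compounds:
compound 1, `Clc1ccc(N2N=NCC2c2ccncc2)cc1`: 257 mg/kg
compound 2, `c1ccc(-n2nncc2-c2ccncc2)cc1`: 78.8 mg/kg
compound 3, `Clc1ccc(-n2nncc2-c2cccnc2)cc1`: 65.8 mg/kg

In a functional assay on the whole organism with Mus musculus as the target, in the maximal electroshock model (on this read-out higher numbers stand for an effect only at larger amounts of compound and lower numbers for an effect already at smaller amounts), compound 3 gives 65.8 mg/kg, the lowest of the three numbers shown. Its gap to compound 2, which gives 78.8 mg/kg, is within the scatter, so the two cannot be placed in order. Compound 1 gives 257 mg/kg in this assay, and the gap from compound 3 to compound 1 is beyond the scatter.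

Compound 4, `Fc1ccc(-n2nncc2-c2cccnc2)cc1`, differs from compound 3 in one place: fluoro in place of chloro on an aromatic carbon. Among the compounds with values here, no measured pair among the three compounds shows this exchange, so there is no step to lean on. A change of one halogen for another on an aromatic carbon is a small one, and the expected step of a 1.3-fold higher number from compound 3 to compound 4 (0.11 log units; within the scatter) in this assay is estimated as none beyond the scatter, with a slight lean towards a higher number. Compound 4 is therefore expected to give 85 mg/kg in this assay, estimated to fall between 40 mg/kg and 180 mg/kg.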

Compound 4, dose for half-maximal effect: 74.6 mg/kg
Compound 4: the middle estimate sits 1.1-fold (0.06 log units) above what was measured; measured number inside the range.
By their numbers in this assay, from the lowest: compounds 3, 4 and 2 (each within the scatter of the next); then compound 1.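

In this assay the exchange of fluoro in place of chloro on an aromatic carbon, para to a large group, gives a 1.1-fold higher number from compound 3 to compound 4 (0.05 log units; within the scatter) and so does not separate the two halogens beyond the scatter. Within the data shown here, this is the first pair that differs in one place only, and it shows that, on this core, the read-out does not depend on which of these two halogens is present. Nothing available gives a reason for this result.

The compounds shown leave open what a group other than a halogen would do at this place, such as a methyl, a methoxy or an amine. Also open, as far as these compounds go, is whether the same exchange of chloro for fluoro would give a similar step on the core of compound 1.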